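The source may hold more compounds than are shown below. What is called first, only, known or untested is meant among the compounds shown, and "the series" means these compounds.

Of the compounds shown here, three sharing one core have been measured in a physicochemical assay for lipophilicity, at pH 7.4; on this read-out lower numbers stand for lower lipophilicity and higher numbers for higher lipophilicity: compound 1 (`CCOc1cc(Cl)c(C(=O)NC(=O)Nc2nc3ccc(CN4CCN(C)CC4)cc3s2)cc1N1CCCC1`) gives 4, compound 2 (`CCOc1cc(Cl)c(C(=O)NC(=O)Nc2nc3ccc(CN4CCN(C)CC4)cc3s2)cc1-n1cccn1`) gives 3.8 and compound 3 (`CCOc1cc(Cl)c(C(=O)NC(=O)Nc2nc3ccc(CN4CCN(C)CC4)cc3s2)cc1-c1ccn[nH]1`) gives 3.9. Compound 3 therefore stands level with the other two, as all three values lie within the scatter of one another. Compound 4 (`CCOc1ccc(C(=O)NC(=O)Nc2nc3ccc(CN4CCN(C)CC4)cc3s2)c(Cl)c1`) carries hydrogen in place of 1H-pyrazol-5-yl on an aromatic carbon. The nearest evidence comes from exchanges at this same carbon: a number 0.10 log units lower from compound 1 to compound 3 (within the scatter), a number 0.10 log units higher from compound 2 to compound 3 (within the scatter) and a number 0.20 log units lower from compound 1 to compound 2 (within the scatter). For the measured compounds named here, none of these exchanges gives a step beyond the scatter, but each replaces one ring with another, and no measured compound carries hydrogen there. They therefore bear on this change only indirectly. Starting from compound 3 at 3.9, a small lowering is expected, not clearly beyond the scatter. The expected step is a number 0.30 log units lower from compound 3 to compound 4 (within the scatter). Compound 4 is estimated at 3.6, with an expected range from 3.2 to 4.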

Compound 4, distribution coefficient: 3.4
The estimate for compound 4 lay 0.20 log units above the measured number; measured number inside the range.
By their numbers in this assay, from the lowest: compound 4; then compounds 2, 3 and 1 (each within the scatter of the next).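

For the compounds shown here, replacing the ring on this aromatic carbon with hydrogen gives the first steps beyond the scatter in this assay: a number 0.50 log units lower from compound 3 to compound 4 (beyond the scatter), a number 0.40 log units lower from compound 2 to compound 4 (beyond the scatter) and a number 0.60 log units lower from compound 1 to compound 4 (beyond the scatter). The three rings stand within the scatter of one another, so at this carbon the read-out separates compound 4, with hydrogen, from all three ring-bearing compounds, but does not separate those rings from each other. Nothing available explains why these steps arise.

From the compounds shown here alone, it remains open whether a smaller substituent on this carbon, such as a fluoro or methoxy group, would read like hydrogen or like the rings. A dimethylamino group or a carboxylic acid there is equally unresolved, and all three steps rest on compound 4 alone.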